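The compounds below may be only part of what the source reports. "The series", "measured", "known", "first", "only" and "open" are said of these compounds alone.

Compound 1, `O=c1c2cnn(-c3ccc(F)cc3)c2ncn1CC1(O)CCN(Cc2ccccc2Cl)CC1`: in an assay on Sf21 cells for inhibition of ubiquitin carboxyl-terminal hydrolase 7 (Homo sapiens), read by spectrophotometry, with stated times of 30 min and 2 h (a lower number here means a stronger inhibitor, a higher number a weaker inhibitor), compound 1 gives 3400 nM.
Compound 2, `O=c1c2cnn(-c3ccc(F)cc3)c2ncn1CC1(O)CCN(Cc2ccc(Br)cc2)CC1`: compound 2 gives 6700 nM.
Compound 3, `COC(=O)c1ccc(CN2CCC(O)(Cn3cnc4c(cnn4-c4ccc(F)cc4)c3=O)CC2)cc1`: compound 3 gives 4500 nM.

The three compounds share one core and differ only in the group on the saturated chain carbon bound to the ring amine nitrogen. Compound 3 stands close to both of the others: a 1.3-fold higher number from compound 1 to compound 3 (0.12 log units; within the scatter) and a 1.5-fold lower number from compound 2 to compound 3 (0.17 log units; within the scatter), and likewise a 2.0-fold higher number from compound 1 to compound 2 (0.29 log units; within the scatter). None of these steps stands out from the scatter, so the three groups tried so far look interchangeable on this read-out.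

Compound 4, `COC(=O)c1ccc(CN2CCC(O)(Cn3cnc4c(cnn4-c4ccc(F)cc4)c3=O)CC2)c(Cl)c1`, is compound 3 with one more change: chloro in place of hydrogen on an aromatic carbon. Compound 1 already carries a chloro on its benzyl ring, and its step to compound 3 was within the scatter, so a chloro at this position has shown no clear effect. The expectation for compound 4 is therefore a step of a 1.3-fold lower number from compound 3 to compound 4 (0.11 log units; within the scatter) in this assay, essentially nothing beyond the scatter. Compound 4 is estimated at 3500 nM, with a likely range from 1500 nM to 8000 nM.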

Compound 4, half-maximal inhibitory concentration: 800 nM
Estimate against measurement, compound 4: 4.4-fold (0.64 log units) above, and the stated range ends above it.
By their numbers in this assay, from the lowest: compound 4; then compounds 1, 3 and 2 (each within the scatter of the next).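

In this assay, among these compounds, one added chloro gives a 5.6-fold lower number from compound 3 to compound 4 (0.75 log units; beyond the scatter), the first step in this set to lie beyond the scatter, so this position on the benzyl ring matters more than the earlier compounds suggested. Read from the other side, adding methoxycarbonyl gives a 4.3-fold lower number from compound 1 to compound 4 (0.63 log units; beyond the scatter), and the whole 2-chloro-4-(methoxycarbonyl)benzyl group in place of the 4-bromobenzyl group gives an 8.4-fold lower number from compound 2 to compound 4 (0.92 log units; beyond the scatter), so the ring carrying both groups gives a lower number than the rings carrying only one substituent. Nothing measured here offers a reason for this gain.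

As far as these compounds go, it remains open whether the gain is specific to chloro or would also appear with fluoro, bromo or methyl at that carbon. From the compounds shown here alone, it is also open whether a carboxylic acid or a primary amide could stand in for the methoxycarbonyl group and keep the lower number.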